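From Nitro to Chloro: Expecting Little Change

The source may hold more compounds than are shown below. What is called first, only, known or untested is meant among the compounds shown, and "the series" means these compounds.

Three compounds sharing one core were tested in an assay for binding affinity to Apoptosis regulator Bcl-2 (Homo sapiens), read by fluorescence polarization, with stated times of 30 min and 20 min, tested at 100 uM; a higher number here means more inhibition at the concentration tested (going by the name of the read-out), a lower number less inhibition. Compound 1 `COc1ccc(Oc2ccccc2-c2ccsc2S(=O)(=O)N2CCN(C(=S)Nc3ccc([N+](=O)[O-])cc3)CC2)cc1OC` gives 16%. Compound 2 `COc1ccc(Oc2ccccc2-c2ccsc2S(=O)(=O)N2CCN(C(=O)Nc3cc(C(F)(F)F)cc(C(F)(F)F)c3)CC2)cc1OC` gives 23%, and compound 3 `COc1ccc(Oc2ccc([N+](=O)[O-])cc2-c2ccsc2S(=O)(=O)N2CCN(C(=O)Nc3ccc([N+](=O)[O-])cc3)CC2)cc1OC` gives 19%. Compound 1 has the lowest of the three numbers, but its gaps to compound 3 and to compound 2 both lie within the usual scatter, so the three cannot be put in order. Compound 4 `COc1ccc(Oc2ccccc2-c2ccsc2S(=O)(=O)N2CCN(C(=S)Nc3ccc(Cl)cc3)CC2)cc1OC` differs from compound 1 in one place: chloro in place of nitro on an aromatic carbon. Among the compounds with values here, no measured pair shows what such a change does in this assay. Since all three measured numbers sit low and close together, no step beyond the scatter is expected. For compound 4 the expected value is 16%, with a range from 5% to 30%. The expected step of no change at the digits printed from compound 1 to compound 4 (within the scatter) stays within the scatter.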

Compound 4, a percentage reported as inhibition, at one concentration (the size of the read-out at that concentration, not a potency): 18%
The estimate for compound 4 lay 2 percentage points below the measured number; the measured number falls inside the stated range.
By their numbers in this assay, from the lowest: compounds 1, 4, 3 and 2 (each within the scatter of the next).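

Within the data shown here, this is the first pair that isolates a change on this aromatic ring, and in this assay chloro in place of nitro gives a number 2 percentage points higher from compound 1 to compound 4 (within the scatter). Nitro carries 2 hydrogen-bond acceptors and chloro none, yet this assay cannot tell the two compounds apart. Nothing available explains this result.

On these data alone, whether an amine or a carboxylic acid at this same place would give a step beyond the scatter remains open. So does whether chloro would behave the same way on the urea compounds, such as compound 3, which carry a carbonyl in place of the thiocarbonyl.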